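Trading ethyl for benzyloxy in a cell assay

The compounds below may be only part of what the source reports. "The series", "measured", "known", "first", "only" and "open" are said of these compounds alone.

Of the compounds shown here, two sharing one core have been tested so far in a functional assay on U-87MG ATCC cells for inhibition, with U-87 MG (Homo sapiens) as the target, read by MTT assay, with a stated time of 72 h; on this read-out higher numbers stand for weaker inhibition and lower numbers for stronger inhibition. Compound 1 `Cc1ccnc(NC(c2ccc(F)cc2)c2ccc3cccnc3c2O)c1` reads > 10000 nM, which is a limit of the assay and not a number. Among the measured compounds shown here, compound 2 `CCc1ccc(C(Nc2cc(C)ccn2)c2ccc3cccnc3c2O)cc1` gives 8900 nM, the only true number available, so its standing rests on very little.

Compound 3 `Cc1ccnc(NC(c2ccc(OCc3ccccc3)cc2)c2ccc3cccnc3c2O)c1` carries benzyloxy in place of ethyl on an aromatic carbon, para to a large group (benzyloxy in place of ethyl on an aromatic carbon). For the measured compounds named here, one measured step bears on this change: an at least 1.1-fold lower number from compound 1 to compound 2 (0.05 log units; that floor lies within the scatter), where ethyl took the place of fluoro at that position. Its floor lies within the scatter, so it offers no firm direction.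

The expected move is therefore slight and towards a lower number, with a 1.4-fold lower number from compound 2 to compound 3 (0.14 log units; within the scatter) estimated to stay within the scatter. Compound 3 is estimated at 6500 nM, with an expected range of 2500 nM to 15000 nM.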

Compound 3, half-maximal inhibitory concentration: 9300 nM
Compound 3: middle estimate off by 1.4-fold (0.16 log units), on the low side, and the stated range covers the measured number.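

In this assay the swap of ethyl for benzyloxy brings a 1.0-fold higher number from compound 2 to compound 3 (0.02 log units; within the scatter) and so shows that this position, para to a large group, takes a far bigger group, with 8 heavy atoms in place of 2 and an added aromatic ring, without a change in the read-out beyond the scatter. Against fluoro the picture is looser, with an at least 1.0-fold lower number from compound 1 to compound 3 (0.03 log units; that floor lies within the scatter) and no direction to be read from it. That step starts from a value for compound 1 that is a limit of the assay and not a number: the limit of > 10000 nM in this assay, at which 1 of the 3 values shown sits.

Going by these compounds, whether a group of another kind at this position, such as an amine or a carboxylic acid, would move the number beyond the scatter stays open. So does whether a change elsewhere on the shared core would do so.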